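The source may hold more compounds than are shown below. What is called first, only, known or untested is meant among the compounds shown, and "the series" means these compounds.

Three compounds already have numbers. Compound 2 `O=c1c(C2N=C(c3ccccc3)SS2)coc2ccccc12` and compound 1 `O=c1c(C2N=C(c3ccccc3)SS2)coc2ccc(F)cc12` share one core, while compound 3 `O=c1c(C(=S)Nc2ccccc2)coc2ccccc12` is built on a different core; how the two cores differ is not broken down here. In a functional assay on PC-3 cells (Homo sapiens) for inhibition, read by sulforhodamine B assay, with a stated time of 48 h, tested at 100 uM (a lower number here means less inhibition of growth, a higher number more inhibition of growth at the concentration tested), compound 2 gives 23%, and compound 1 gives 32%. For the measured compounds named here, the single change between these two is fluoro in place of hydrogen on an aromatic carbon, and the step it made is a number 9 percentage points higher from compound 2 to compound 1 (within the scatter). In this assay compound 3 gives 63%, the highest of the three, standing beyond the scatter above each of the other two.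

Compound 4 `O=c1c(C(=S)Nc2ccccc2)coc2ccc(F)cc12` has not yet been measured. Going by the values given here, it differs from compound 3 by fluoro in place of hydrogen on an aromatic carbon, the same change as the one made from compound 2 to compound 1, at a place described in the same words on the six-membered carbon ring of the fused system. This change has been seen once among these compounds, and that one step stayed within the scatter. The expectation therefore rests on the step of a number 9 percentage points higher from compound 2 to compound 1 (within the scatter): a similar, small step is expected here, with no reason from the data to expect a larger one. The step expected is a number 5 percentage points higher from compound 3 to compound 4 (within the scatter). Compound 4 is thus estimated at 68%, with a likely range from 52% to 84%, remaining close to compound 3.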

Compound 4, percent growth inhibition at one concentration: 45%
Compound 4: the middle estimate sits 23 percentage points above what was measured, outside the stated range (below it).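

In this assay, the change from hydrogen to fluoro on an aromatic carbon did not carry over from one core to the other, and the new step is a number 18 percentage points lower from compound 3 to compound 4 (beyond the scatter). Set side by side, the two steps differ in size and in direction: the same change on two cores in this assay, a number 9 percentage points higher (within the scatter) from compound 2 to compound 1 and a number 18 percentage points lower (beyond the scatter) from compound 3 to compound 4, 27 percentage points apart, beyond the scatter of two such steps. For the compounds shown here, this shows that a result for this change on the core of compound 1 cannot simply be transferred to the core of compound 3, but with only one pair on each core, one place on the ring and one tested concentration, it does not show why the cores differ, nor whether fluoro would lower the number on other compounds built on the core of compound 3.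

The compounds shown leave open whether a chloro group, a methoxy group or an amine in the same place would also give different steps on the two cores. They also leave open whether a carboxylic acid there would follow the pattern of the pair on the core of compound 1, that of the pair on the core of compound 3, or neither.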